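Cyclohexyl to 4-fluorobenzyl on the chain carbon of compound 2

A few compounds are considered here, and "the series" means these few. Any claim that something is new, unique, unknown or untested is made for them only; others in the source may bear on it.

Measured so far in an assay on CHO cells for antagonist activity at transient receptor potential cation channel subfamily V member 1 (Homo sapiens), read by FLIPR; on this read-out lower numbers stand for stronger inhibition and higher numbers for weaker inhibition:
compound 1 `CC1CCN(c2nc(C(F)(F)F)ccc2CNC(=O)C(c2ccc(NS(C)(=O)=O)c(F)c2)C2CCCCC2)CC1`: 31.1 nM
compound 2 `CS(=O)(=O)Nc1ccc(C(C(=O)NCc2ccc(C(F)(F)F)nc2SC2CCCCC2)C2CCCCC2)cc1F`: "active" (no number reported)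
compound 3 `CC1CCN(c2nc(C(F)(F)F)ccc2CNC(=O)C(Cc2ccccc2)c2ccc(NS(C)(=O)=O)c(F)c2)CC1`: 65.9 nM

Compound 2 stands only as active in this assay; no number is known for it, so it cannot be placed against compound 1 or compound 3 on the numbers.

Compound 4 `CS(=O)(=O)Nc1ccc(C(Cc2ccc(F)cc2)C(=O)NCc2ccc(C(F)(F)F)nc2SC2CCCCC2)cc1F` differs from compound 2 in one place: 4-fluorobenzyl in place of cyclohexyl on a saturated chain carbon bound to an aromatic carbon and a carbonyl carbon. Among the measured compounds shown here, the one measured step that bears on this is a 2.1-fold higher number from compound 1 to compound 3 (0.33 log units; beyond the scatter), the same exchange save for the fluorine on the entering group and a different core. A modest weakening of similar size is therefore expected here, pointing to a higher number in this assay for compound 4 than for compound 2. With no anchor value for compound 2, the expectation for compound 4 is placed near the measured compounds: compound 4 is estimated at 90 nM, within 25 nM to 350 nM.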

Compound 4, inhibition constant: "active" (no number reported)
Compound 4: no number reported, so the estimate cannot be set against anything.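

In this assay compound 2 and compound 4 both stand only as active, so no step can be read between them, and no evidence bears on this result.
The compounds shown leave open how far 4-fluorobenzyl in place of cyclohexyl shifts the number on the core of compound 2.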